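Replacing 4-methoxyphenyl with 3-bromophenyl

The source may hold more compounds than are shown below. What is called first, only, known or untested is meant among the compounds shown, and "the series" means these compounds.

Among the measured compounds shown here, in a functional assay on KB cells (Homo sapiens) for antiproliferative activity, read by MTT assay, with a stated time of 72 h (a lower number here means a stronger inhibitor, a higher number a weaker inhibitor), compound 2 `COc1ccc(-c2sccc2-c2cc(OC)c(OC)c(OC)c2)cc1` gives 8880 nM, the only true number available so far. Compound 1 `CCOC(=O)c1cc(-c2cc(OC)c(OC)c(OC)c2)c(-c2cccc(Br)c2)s1`, which also carries a 3-bromophenyl group, reads > 100000 nM, and this is a limit of the assay rather than a number. Compound 2 therefore has no measured neighbour to be ranked against. The next structure is compound 3 `COc1cc(-c2ccsc2-c2cccc(Br)c2)cc(OC)c1OC`, with 3-bromophenyl in place of 4-methoxyphenyl on an aromatic carbon, next to the ring sulfur (3-bromophenyl in place of 4-methoxyphenyl on an aromatic carbon). For the measured compounds named here, no measured pair yet shows what this exchange does on its own, so any forecast is loose. With compound 1 at its limit of > 100000 nM as the only hint, a moderate weakening in this assay is expected rather than a gain. The estimated change is a 3.4-fold higher number from compound 2 to compound 3 (0.53 log units; beyond the scatter). For compound 3 the expected value is 30000 nM, with an estimated range from 6000 nM to 100000 nM.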

Compound 3, half-maximal inhibitory concentration: > 100000 nM
Compound 3 gave a limit, no number (the forecaster's own chance of this, stated with the estimate: 30%); at least 3.3-fold (0.52 log units) between middle value and limit.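

Among the compounds shown here, on an aromatic carbon next to the ring sulfur, 3-bromophenyl in place of 4-methoxyphenyl is the first exchange here that can be read on its own, and in this assay it gives an at least 11-fold higher number from compound 2 to compound 3 (1.05 log units; beyond the scatter). The measurable activity of compound 2 therefore depends on which aryl group sits at this position, and this exchange goes clearly beyond the scatter in the weakening direction. The full size of the loss stays unknown because compound 3 gives a limit, not a number: the limit of > 100000 nM in this assay, at which 2 of the 3 values shown sit.

As far as these compounds go, compound 1 and compound 3 both give limits, so the step between them cannot be read, and what ethoxycarbonyl does on this core stays open. Also open, from the compounds shown here alone, is whether a phenyl ring carrying an amine or a carboxylic acid at this position would keep the activity of compound 2.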